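The source may report more compounds than this note shows. Statements on the series, on what has been measured and on what is new or still open speak of the compounds shown alone.

Compound 1 `COc1ccc(Nc2nc(-c3cccc(F)c3)nc3ccc(F)cc23)cc1` gives 42300 nM in a functional assay on HT29-AK cells (Homo sapiens) for cytotoxicity, read by MTT assay, with a stated time of 48 h; a lower number here means a stronger inhibitor, a higher number a weaker inhibitor.
Compound 2 `Fc1ccc(Nc2nc(-c3cccc(F)c3)nc3ccc(F)cc23)cc1` gives a limit of the assay, > 50000 nM.
Compound 3 `Fc1cccc(Nc2nc(-c3cccc(F)c3)nc3ccc(F)cc23)c1` gives a limit of the assay, > 50000 nM.

The three share one core and differ only in the aryl group on the amine nitrogen. Compound 2 stands at the limit of > 50000 nM in this assay, at which 2 of the 3 values shown sit, so its position among the measured compounds is known only as a limit, not as a number. Compound 4 `Fc1cccc(-c2nc(Nc3cccc(Cl)c3)c3cc(F)ccc3n2)c1` has not been measured; it differs from compound 2 by 3-chlorophenyl in place of 4-fluorophenyl on a nitrogen on an aromatic ring. For the measured compounds named here, the steps that bear on this change give no readable size: an at least 1.1-fold higher number from compound 1 to compound 2 (0.07 log units; that floor lies within the scatter), an at least 1.1-fold higher number from compound 1 to compound 3 (0.07 log units; that floor lies within the scatter), and a step that the two limits leave unreadable from compound 2 to compound 3. No step beyond the scatter is therefore expected in this assay for compound 4, and its value is estimated at 60000 nM, within 20000 nM to 200000 nM. That estimate means a step that the limit leaves unreadable from compound 2 to compound 4, with a good chance that only a limit is reported again.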

Compound 4, half-maximal inhibitory concentration: > 50000 nM
Compound 4 ended at the assay's limit (the forecaster's own chance of this, stated with the estimate: 65%); the middle value lies beyond the limit too.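

In this assay, for the compounds shown here, 3-chlorophenyl on this nitrogen gives no number, only a limit, so the chloro group adds a third aryl group to those that stop at the limit: the limit of > 50000 nM in this assay, at which 3 of the 4 values shown sit. The one readable step is an at least 1.1-fold higher number from compound 1 to compound 4 (0.07 log units; that floor lies within the scatter), while the steps linking compound 4 to compound 2 and compound 3 cannot be read.

On these data alone, how these halogenated aryl groups rank beyond the limit stays open. So does whether an amine or a carboxylic acid on this aryl ring would bring a value clear of the limit.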